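Bromo for chloro in a small antiproliferative set

The source may report more compounds than this note shows. Statements on the series, on what has been measured and on what is new or still open speak of the compounds shown alone.

In a functional assay on L1210 cells (Mus musculus) for antiproliferative activity, with a stated time of 48 h (a lower number here means a stronger inhibitor, a higher number a weaker inhibitor), compound 1 (`Nc1ccc(/C=C/C(=O)c2ccccc2)cc1`) gives 88000 nM and compound 2 (`Nc1ccc(/C=C/C(=O)c2ccc(Cl)cc2)cc1`) gives 111000 nM as its reading, so compound 2 stands level with compound 1 within the scatter. Compound 3 (`Nc1ccc(/C=C/C(=O)c2ccc(Br)cc2)cc1`) differs from compound 2 by bromo in place of chloro on an aromatic carbon. Among the compounds with values here, the one measured step bearing on this change, chloro in place of hydrogen, is small (a 1.3-fold higher number from compound 1 to compound 2 (0.10 log units; within the scatter)), so no step beyond the scatter is expected in this assay for this swap. The expected change (a 1.0-fold lower number from compound 2 to compound 3 (0.00 log units; within the scatter)) stays within the scatter. Compound 3 is estimated at 110000 nM with an expected range from 60000 nM to 200000 nM around it.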

Compound 3, half-maximal inhibitory concentration: 90000 nM
Estimate against measurement, compound 3: 1.2-fold (0.09 log units) above, and the stated range covers the measured number.
By their numbers in this assay, from the lowest: compounds 1, 3 and 2 (each within the scatter of the next).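

With bromo on this aromatic carbon, para to a large group, this assay shows a 1.2-fold lower number from compound 2 to compound 3 (0.09 log units; within the scatter) and a 1.0-fold higher number from compound 1 to compound 3 (0.01 log units; within the scatter). The earlier pair had shown only that chloro reads level with hydrogen here, and now hydrogen, chloro and bromo all stand within the scatter of one another. No measurement given here accounts for this level reading.

As far as these compounds go, whether a group of another kind at this position, such as a carboxylic acid, a methoxy group or a longer chain, would read apart from these three remains open. Also open, from the compounds shown here alone, is whether this position matters at all in this assay.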